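A few compounds are considered here, and "the series" means these few. Any claim that something is new, unique, unknown or untested is made for them only; others in the source may bear on it.

Measured compounds:
compound 1, `NC(=O)OC(CCN1CCN(c2ccccc2)CC1)c1cccc(Cl)c1`: 59%
compound 2, `NC(=O)OC(CCN1CCN(c2ccccc2)CC1)c1cccc([N+](=O)[O-])c1`: 48%

Both numbers come from a functional assay on the whole organism for inhibition, with Mus musculus as the target, in the writhing test, with a stated time of 1 h, at a dose of 10 mg/kg by the oral route; a lower number here means less inhibition, a higher number more inhibition at the dose given (going by the name of the read-out). Of the two, compound 2 stands lowest, giving 48% in this assay; its nearest neighbour is compound 1, which lies higher by a margin beyond the scatter, the step being a number 11 percentage points lower from compound 1 to compound 2 (beyond the scatter) for nitro in place of chloro on an aromatic carbon.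

The unmeasured compound 3, `COc1ccc(C(CCN2CCN(c3ccccc3)CC2)OC(N)=O)cc1`, differs from compound 2 by 4-methoxyphenyl in place of 3-nitrophenyl on a saturated chain carbon bound to an oxygen next to a carbonyl group and a saturated chain carbon. Among the measured compounds shown here, the one measured step that bears on this change is a number 11 percentage points lower from compound 1 to compound 2 (beyond the scatter): it alters the same aromatic ring on the same saturated chain carbon, though it exchanges a different pair of groups, and it moved the read-out only modestly. With just this single step to go by, the direction for a 4-methoxyphenyl cannot be read off, and the two measured compounds sit within a modest span of each other, so compound 3 is expected to stay close to that span in this assay.

Compound 3 is estimated to give 55% in this assay, in the range 40% to 70%. This corresponds to an expected step of a number 7 percentage points higher from compound 2 to compound 3 (within the scatter), upward but within the usual scatter.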

Compound 3, a percentage reported as inhibition, in the whole organism at one dose (the size of the read-out at that dose, not a potency): 43%
Compound 3: middle estimate off by 12 percentage points, on the high side; measured number inside the range.
By their numbers in this assay, from the lowest: compounds 3 and 2 (each within the scatter of the next); then compound 1.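

In this assay, the new group on the saturated chain carbon bound to an oxygen next to a carbonyl group gives a second reading of this position: the change to 4-methoxyphenyl from 3-nitrophenyl leaves a number 5 percentage points lower from compound 2 to compound 3 (within the scatter) and so does not separate these two groups. Set against 3-chlorophenyl, the same group gives a number 16 percentage points lower from compound 1 to compound 3 (beyond the scatter) and, with the earlier nitro step, this makes compound 1 the one compound of the three that stands clear of both others, while the two replacements of its 3-chlorophenyl group, though different in kind, end up level within the scatter. Nothing at hand accounts for this ordering.

Compound 3 differs from compound 1 in both the group and its place on the ring, so the compounds shown cannot say whether the methoxy group itself or its 4-position goes with the lower number. A 3-methoxyphenyl or a 4-chlorophenyl group would separate these two changes, and a 3-aminophenyl group would show whether the position also accepts an amine.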